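Indole Replaces Aminothiophene on the Carbonyl Carbon

This account rests on a few compounds, and the source may have more. Where it says the series, first, only, none or still open, it means among the compounds named here.

Of the compounds shown here, three sharing one core have been measured in a functional assay on MCF7 cells (Homo sapiens) for antiproliferative activity, read by XTT assay, with a stated time of 72 h; on this read-out lower numbers stand for stronger inhibition and higher numbers for weaker inhibition. Compound 3 `COc1ccc(-c2cc3ccccc3nc2/C=C/C(=O)c2sccc2N)cc1` gives > 10000 nM, which is a limit of the assay rather than a number, (the limit of > 10000 nM in this assay, at which 1 of the 3 values shown sits). Compound 1 `COc1ccc(-c2cc3ccccc3nc2/C=C/C(=O)c2ccc(OC)cc2OC)cc1` gives 6260 nM, and compound 2 `COc1ccc(-c2cc3ccccc3nc2/C=C/C(=O)c2ccsc2)cc1` gives 6010 nM. The step of a 1.0-fold lower number from compound 1 to compound 2 (0.02 log units; within the scatter) shows one swap on the carbonyl carbon staying within the scatter. The steps of an at least 1.5-fold higher number from compound 1 to compound 3 (0.20 log units; that floor lies within the scatter) and an at least 1.6-fold higher number from compound 2 to compound 3 (0.22 log units; that floor lies within the scatter) give only a floor for compound 3. Compound 4 `COc1ccc(-c2cc3ccccc3nc2/C=C/C(=O)c2c[nH]c3ccccc23)cc1` differs from compound 3 by 1H-indol-3-yl in place of 3-aminothiophen-2-yl on a carbonyl carbon. Earlier swaps on the carbonyl carbon stayed within the scatter or reached only a floor. Compound 4 is therefore expected to show a step of an at least 1.4-fold lower number from compound 3 to compound 4 (0.15 log units; that floor lies within the scatter). The estimate for compound 4 is 7000 nM, within 2500 nM to 20000 nM.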

Compound 4, half-maximal inhibitory concentration: > 10000 nM
Compound 4 gave a limit, no number (the forecaster's own chance of this, stated with the estimate: 30%); middle value at least 1.4-fold (0.15 log units) from the limit.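

Compound 4 sits at a limit of the assay rather than at a number, the second compound shown to do so: the limit of > 10000 nM in this assay, at which 2 of the 4 values shown sit.

Against the two compounds with numbers it gives only floors, an at least 1.6-fold higher number from compound 2 to compound 4 (0.22 log units; that floor lies within the scatter) and an at least 1.5-fold higher number from compound 1 to compound 4 (0.20 log units; that floor lies within the scatter), and the step between the two limits cannot be read. So a group with a six-membered aromatic ring added to the five-membered one brought no readable gain on this carbonyl carbon.

As far as these compounds go, how compound 3 and compound 4 truly rank stays unknown. From the compounds shown here alone, whether a pyridine or a phenyl ring carrying a carboxylic acid here would give a clearly lower number remains open.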